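The source may hold more compounds than are shown below. What is called first, only, known or untested is meant among the compounds shown, and "the series" means these compounds.

Compound 1 `Cc1cccc(Cn2c(CN3CCN(C(=O)c4cccs4)CC3)nc3ccccc32)c1` is measured in an assay on isolated protein for inhibition of aldehyde dehydrogenase 1A1 (Homo sapiens), read by spectrophotometry, tested at 10 uM (a higher number here means more inhibition at the concentration tested (going by the name of the read-out), a lower number less inhibition), where compound 1 gives 60.8%. Compound 3 `CC(C)=CCn1c(CN2CCN(C(=O)C3CC3)CC2)nc2ccccc21` gives 74.3% in this assay and compound 2 `Cc1ccccc1Cn1c(CN2CCN(C(=O)C3CC3)CC2)nc2ccccc21` gives 29.1%, so compound 1 stands second of the three, beyond the scatter on either side. Among the compounds with values here, the one measured step, a number 45.2 percentage points higher from compound 2 to compound 3 (beyond the scatter), swaps the group on the saturated chain carbon bound to the aromatic nitrogen. Compound 4 `Cc1cccc(Cn2c(CN3CCN(C(=O)CC(C)C)CC3)nc3ccccc32)c1` instead alters the carbonyl substituent: isobutyl in place of thiophen-2-yl on a carbonyl carbon. Within the data shown here, no measured pair varies that position, so the step from compound 2 to compound 3 does not bear on it directly. Compound 4 is therefore expected near 50%, with a range of 22% to 76%, and the estimated step of a number 10.8 percentage points lower from compound 1 to compound 4 (beyond the scatter) is wide in its uncertainty.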

Compound 4, a percentage reported as inhibition, at one concentration (the size of the read-out at that concentration, not a potency): 71.4%
Compound 4: the middle estimate sits 21.4 percentage points below what was measured; the range from low to high includes it.
By their numbers in this assay, from the lowest: compound 2; then compound 1; then compounds 4 and 3 (each within the scatter of the next).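

In this assay the carbonyl substituent proves to matter, with a number 10.6 percentage points higher from compound 1 to compound 4 (beyond the scatter) as the first step read at this position. An aromatic ring on the carbonyl carbon is therefore not needed for this level of inhibition, since isobutyl, which has no ring, gives more than thiophen-2-yl on the core of compound 1. Nothing at hand explains this step. From the compounds shown here alone, it remains open whether the step would hold with the 2-methylprop-1-en-1-yl group of compound 3 in place on the chain carbon. Also open, going by these compounds, is how a longer chain, an amine or a carboxylic acid would fare on the carbonyl carbon.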